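The source may hold more compounds than are shown below. What is called first, only, known or untested is meant among the compounds shown, and "the series" means these compounds.

Measured compounds:
compound 1 `COC(=O)c1c(C)cccc1OC(=O)COc1cc(O)c2c(=O)cc(-c3ccccc3)oc2c1` — 37200 nM
compound 2 `COC(=O)c1cccc(Cl)c1OC(=O)COc1cc(O)c2c(=O)cc(-c3ccccc3)oc2c1` — 38700 nM

In a functional assay on cells (T-cell, Mus musculus, strain BALB/c) for inhibition, read by MTT assay, with a stated time of 72 h (a higher number here means a weaker inhibitor, a lower number a stronger inhibitor), compound 1 gives 37200 nM and compound 2 gives 38700 nM. Of the two numbers compound 2 gives the higher one, with compound 1 nearest, but a 1.0-fold higher number from compound 1 to compound 2 (0.02 log units; within the scatter) lies within the scatter, so the two compounds cannot be separated on these data.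

Compound 3 `COC(=O)c1ccc(Br)cc1OC(=O)COc1cc(O)c2c(=O)cc(-c3ccccc3)oc2c1` is not yet measured. It differs from compound 2 in one place: a group of 11 heavy atoms (8 carbon, 2 oxygen, 1 bromine; one six-membered aromatic ring of carbon only) in place of a group of 11 heavy atoms (8 carbon, 2 oxygen, 1 chlorine; one six-membered aromatic ring of carbon only), on an oxygen next to a carbonyl group. Going by the values given here, the only measured step that bears on this change is a 1.0-fold higher number from compound 1 to compound 2 (0.02 log units; within the scatter), in which a halogen-bearing ring took the place of a methyl-bearing ring on the same oxygen next to a carbonyl group, and the number barely moved. On that basis the exchange of one halogen-bearing ring for another is expected to give a step of a 1.0-fold lower number from compound 2 to compound 3 (0.01 log units; within the scatter) that stays within the scatter, with no direction beyond it. Compound 3 is therefore estimated at 38000 nM in this assay, with a range from 19000 nM to 76000 nM.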

Compound 3, half-maximal inhibitory concentration: 17600 nM
The estimate for compound 3 lay 2.2-fold (0.33 log units) above the measured number; measured number outside the range, below it.
By their numbers in this assay, from the lowest: compound 3; then compounds 1 and 2 (each within the scatter of the next).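

In this assay, the group on the oxygen next to a carbonyl group does affect the read-out, which the first two compounds could not show: replacing 2-chloro-6-(methoxycarbonyl)phenyl with the bromine-bearing ring gives a 2.2-fold lower number from compound 2 to compound 3 (0.34 log units; beyond the scatter), and replacing the methyl-bearing ring with the same bromine-bearing ring gives a 2.1-fold lower number from compound 1 to compound 3 (0.33 log units; beyond the scatter). Both steps are modest but beyond the scatter, so compound 3 has the lowest number of the three, and exchanging one halogen-bearing ring for another is not neutral here, even though the exchange of the chlorine-bearing ring for the methyl-bearing ring moved nothing measurable. No supporting data bear on why this step occurs.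

The step from compound 2 to compound 3 changes both the halogen and its place on the ring, and these compounds do not separate the two contributions, so a chlorine-bearing ring with the substitution pattern of compound 3 would be the direct test. Also open, from the compounds shown here alone, is how this position responds to groups outside the methyl and halogen set, such as an amine on the ring or a carboxylic acid in place of the methoxycarbonyl group.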